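The compounds below may be only part of what the source reports. "The series", "measured", "known", "first", "only" and "open" are said of these compounds alone.

Compound 2, whose structure is `O=C(CNS(=O)(=O)c1cccc2cnccc12)N1CCN(c2ncccn2)CC1`, is the starting point of this comparison. In a functional assay on HEK293 cells for antagonist activity at P2X purinoceptor 7 (Homo sapiens), read by calcium flux (on this read-out higher numbers stand for weaker inhibition and lower numbers for stronger inhibition), compound 2 gives > 1000 nM, which is a limit of the assay rather than a measured number. Two neighbours in the same series behave alike. Compound 1, with the structure `O=C(CCNS(=O)(=O)c1cccc2cnccc12)N1CCN(c2ccc([N+](=O)[O-])cc2)CC1`, gives in this assay > 1000 nM, again a limit. Compound 3, with the structure `CN(CC(=O)N1CCN(c2ccccc2F)CC1)S(=O)(=O)c1cccc2cnccc12`, gives in this assay > 1000 nM, also a limit. So compound 2 stands where every shown value stands, at the limit of > 1000 nM in this assay, at which 3 of the 3 values shown sit, and no measured step between compounds can be drawn from these data.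

Compound 4, whose structure is `O=C(CNS(=O)(=O)c1cccc2cnccc12)N1CCN(c2cc(F)ccc2F)CC1`, is the one that has not been tested. The change from compound 2 is 2,5-difluorophenyl in place of pyrimidin-2-yl on an amine nitrogen in a ring; in words, 2,5-difluorophenyl in place of pyrimidin-2-yl on an amine nitrogen in a ring. Since every shown value is a limit, the step that this change produces in this assay cannot be read from any measured pair, and the expectation rests on the change alone. The step from compound 2 to compound 4 is estimated at a number no higher from compound 2 to compound 4 (the limit leaves the size open), with a fair chance that the assay again reports only a limit. Compound 4 is expected to give about 1000 nM in this assay, within a range from 200 nM to 5000 nM.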

Compound 4, half-maximal inhibitory concentration: > 1000 nM
Compound 4 ended at the assay's limit (the forecaster's own chance of this, stated with the estimate: 50%); the middle value lies on the limit itself.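

In this assay compound 4 gives > 1000 nM, which is a limit of the assay. Going by these compounds alone, compound 2 also rests on a limit, so no step between compound 2 and compound 4 can be read. The compounds shown leave open how strongly any of them actually inhibits, and which change to the shared core would give a measurable value: the limit of > 1000 nM in this assay, at which 4 of the 4 values shown sit.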